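Adding an Ethyl Where a Methyl Once Mattered

A few compounds are considered here, and "the series" means these few. Any claim that something is new, unique, unknown or untested is made for them only; others in the source may bear on it.

Within the data shown here, compound 2 `Cc1cn(-c2cc(NC(=O)c3cccc(Nc4nc(-c5cccnc5)cs4)c3)cc(C(F)(F)F)c2)cn1` stands highest of the two numbers measured so far: in a functional assay on KU812 cells (Homo sapiens) for antiproliferative activity (on this read-out lower numbers stand for stronger inhibition and higher numbers for weaker inhibition), compound 2 gives 2730 nM, while compound 1 `Cc1cn(-c2cc(NC(=O)c3ccc(C)c(Nc4nc(-c5cccnc5)cs4)c3)cc(C(F)(F)F)c2)cn1` gives 30 nM. Those two differ only in a 91-fold higher number from compound 1 to compound 2 (1.96 log units; beyond the scatter). Compound 3 `CCc1ccc(C(=O)Nc2cc(-n3cnc(C)c3)cc(C(F)(F)F)c2)cc1Nc1nc(-c2cccnc2)cs1` goes back in the other direction with a longer group: ethyl in place of hydrogen on an aromatic carbon. Because the step of a 91-fold higher number from compound 1 to compound 2 (1.96 log units; beyond the scatter) was large, putting an alkyl group back on the same carbon is expected to lower the number strongly again. Compound 3 is therefore expected to show a 46-fold lower number from compound 2 to compound 3 (1.66 log units; beyond the scatter), with an estimate of 60 nM and a range from 15 nM to 300 nM.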

Compound 3, half-maximal inhibitory concentration: 945 nM
Compound 3: the middle estimate sits 16-fold (1.20 log units) below what was measured, outside the stated range (above it).
By their numbers in this assay, from the lowest: compound 1; then compound 3; then compound 2.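

On this carbon of the shared core, ethyl gives back only a modest part of what removing methyl cost: the gain a 2.9-fold lower number from compound 2 to compound 3 (0.46 log units; beyond the scatter) is small beside the remaining gap a 32-fold higher number from compound 1 to compound 3 (1.50 log units; beyond the scatter) in this assay. An alkyl group here can therefore lower the number, but methyl and ethyl are not interchangeable at this position. Nothing available explains the difference between these two groups. Still open, on these data alone, is how a fluorine, a methoxy group or a longer chain such as propyl would fare on this same carbon.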